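The compounds below may be only part of what the source reports. "The series", "measured", "known", "first", "only" and "open" are said of these compounds alone.

Of the compounds shown here, three sharing one core have been tested in a functional assay on HeLa cells (Homo sapiens) for inhibition, read by sulforhodamine B assay, with a stated time of 48 h; a lower number here means a stronger inhibitor of growth, a higher number a weaker inhibitor of growth. Compound 1 `Cc1cc(=O)oc2cc(N=C=[Se])ccc12` gives 12000 nM, and compound 3 `CCCOC(=[Se])Nc1ccc2c(C)cc(=O)oc2c1` gives 23000 nM, so these two sit within the usual scatter of each other. Compound 2 `CCOC(=[Se])Nc1ccc2c(C)cc(=O)oc2c1` reads > 100000 nM, which is a limit of the assay and not a number.

The next compound to be tested is compound 4 `CCCCNC(=[Se])Nc1ccc2c(C)cc(=O)oc2c1`, which carries butylamino in place of propoxy on a saturated chain carbon bound to a nitrogen on an aromatic ring.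

Within the data shown here, two measured steps bear on this change. Replacing the group on the core gave an at least 8.3-fold higher number from compound 1 to compound 2 (0.92 log units; beyond the scatter), and a single added methyl on the chain gave an at least 4.3-fold lower number from compound 2 to compound 3 (0.63 log units; beyond the scatter). Both steps lie beyond the scatter, so this part of the molecule clearly matters, and even a small edit can shift the result. The second step is the closer guide, and it went towards a lower number. Among the measured compounds shown here, no measured compound carries butylamino, however, so this is weak support.

A modest move towards a lower number is therefore expected in this assay, though it may stay within the scatter. The expected change is a 2.1-fold lower number from compound 3 to compound 4 (0.32 log units; beyond the scatter). For compound 4 the estimated value is 11000 nM, with an expected range from 2500 nM to 50000 nM.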

Compound 4, concentration for 50% growth inhibition: 5200 nM
Estimate against measurement, compound 4: 2.1-fold (0.33 log units) above; measured number inside the range.
By their numbers in this assay, from the lowest: compound 4; then compounds 1 and 3 (each within the scatter of the next). At a limit, above all of these: compound 2.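

In this assay, among these compounds, butylamino in place of propoxy gives a 4.4-fold lower number from compound 3 to compound 4 (0.65 log units; beyond the scatter), the first evidence that this position accepts a chain joined through nitrogen as well as one joined through oxygen, and that growth inhibition can improve with that swap. Compound 2 stands at a limit of the assay and not at a true number: the limit of > 100000 nM in this assay, at which 1 of the 4 values shown sits. Butylamino in place of ethoxy gives an at least 19-fold lower number from compound 2 to compound 4 (1.28 log units; beyond the scatter), so among the three compounds that carry a chain here, the group at this position separates a compound at that limit from compound 4, the one with the lowest number of the three.

This single change does several things at once: it swaps oxygen for nitrogen, adds a hydrogen-bond donor and adds one heavy atom, and the compounds shown cannot tell which of these accounts for the step. Propylamino would isolate the swap of oxygen for nitrogen from compound 3, butoxy would isolate it from compound 4, and a longer chain on the nitrogen would show whether the trend in chain length continues beyond butylamino.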